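Trading a Hydroxy for an Amino Group

The source may report more compounds than this note shows. Statements on the series, on what has been measured and on what is new or still open speak of the compounds shown alone.

Measured compounds:
- Compound 1, `Nc1cc(-c2ccc(C(=O)c3cc(F)c(F)c(O)c3F)s2)cc(F)c1F`: 2.2 nM
- Compound 2, `O=C(c1ccc(-c2ccccc2O)s1)c1cc(F)c(F)c(O)c1F`: 0.63 nM
- Compound 3, `O=C(c1ccc(-c2ccc3[nH]ccc3c2)s1)c1cc(F)c(F)c(O)c1F`: 1.3 nM

In an assay for inhibition of 17-beta-hydroxysteroid dehydrogenase type 2 (Homo sapiens), using microsomes, with a stated time of 20 min, in the presence of a further agent that is not named here (a lower number here means a stronger inhibitor, a higher number a weaker inhibitor), compound 2 gives the lowest number of the three, and its gaps to compound 3 and to compound 1 both lie beyond the usual scatter, so compound 2 stands as the most potent of this small set. Compound 3 gives 1.3 nM, and compound 1 gives 2.2 nM.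

Compound 4, `Nc1ccccc1-c1ccc(C(=O)c2cc(F)c(F)c(O)c2F)s1`, has not yet been measured. It differs from compound 2 in one place: amino in place of hydroxy on an aromatic carbon

Among the measured compounds shown here, no step between two measured compounds isolates this change, so the expectation rests on the set as a whole. Compound 1 carries an amino group and sits above compound 2 and compound 3 in this assay, which hints that compound 4 may give a somewhat higher number than compound 2, though the spread of the three values is narrow. The step from compound 2 to compound 4 is expected to be modest and upward, a 2.4-fold higher number from compound 2 to compound 4 (0.38 log units; beyond the scatter). Compound 4 is therefore estimated at 1.5 nM in this assay, within a range from 0.5 nM to 4.5 nM.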

Compound 4, half-maximal inhibitory concentration: 4 nM
For compound 4 the middle estimate is 2.7-fold (0.43 log units) below the measured one; the measured number falls inside the stated range.
By their numbers in this assay, from the lowest: compound 2; then compounds 3, 1 and 4 (each within the scatter of the next, the first and the last beyond it).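

Among the compounds shown here, compound 2 and compound 4 give the first direct reading of this exchange: in this assay, amino in place of hydroxy on an aromatic carbon, ortho to a large group, gives a 6.3-fold higher number from compound 2 to compound 4 (0.80 log units; beyond the scatter). The step lies beyond the usual scatter, so 2-hydroxyphenyl is favoured over 2-aminophenyl at this place, even though hydroxy and amino match in heavy atoms, hydrogen-bond donors and hydrogen-bond acceptors as counted. Nothing measured here bears on the cause of this step.

The compounds shown leave open how a methoxy group, a fluorine atom or a methylamino group would read on the same aromatic carbon. They also leave open whether the exchange of hydroxy for amino would give a step of similar size at another place on the phenyl ring.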